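The compounds below may be only part of what the source reports. "The series", "measured", "known", "first", "only" and "open" are said of these compounds alone.

The compounds share the core of compound 1 `O=C(NC1(C(=O)NO)CCCCC1)c1ccc(C#Cc2ccccc2)cc1`, which in a physicochemical assay for solubility (on this read-out lower numbers stand for lower solubility and higher numbers for higher solubility), reports only a limit, < 1000 nM. Compound 3 `O=C(NC1(C(=O)NO)CCSCC1)c1ccc(C#Cc2ccccc2)cc1` gives 1000 nM in this assay. Compound 2 `NC(=O)C[C@H](NC(=O)c1ccc(C#Cc2ccccc2)cc1)C(=O)NO` gives 61000 nM in this assay, the highest of the two numbers available, and its nearest neighbour is compound 3, a gap that lies beyond the scatter. Compound 4 `NC[C@H](NC(=O)c1ccc(C#Cc2ccccc2)cc1)C(=O)NO` differs from compound 2 by amino in place of carbamoyl on a saturated chain carbon, two bonds along the chain from an amide-type nitrogen and a carbonyl carbon. For the measured compounds named here, no step between measured compounds matches this change, so the expectation rests on compound 2 alone. A moderate rise beyond the scatter is expected in this assay, a 2.5-fold higher number from compound 2 to compound 4 (0.39 log units; beyond the scatter). In this assay compound 4 is expected to reach about 150000 nM, estimated to fall between 40000 nM and 600000 nM.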

Compound 4, solubility: 13000 nM
Compound 4: the middle estimate sits 12-fold (1.06 log units) above what was measured; the whole stated range lies above it.
By their numbers in this assay, from the lowest: compound 3; then compound 4; then compound 2.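

In this assay, for the compounds shown here, this is the first step that can be read between two compounds differing in one place: with amino in place of carbamoyl on a saturated chain carbon, the result is a 4.7-fold lower number from compound 2 to compound 4 (0.67 log units; beyond the scatter). The number at this position therefore depends on the group it carries, and carbamoylmethyl gives the higher number of the two groups compared. Nothing shown accounts for the direction or size of this step.

The compounds shown leave open how a carboxylic acid or a longer chain ending in an amine would read at this place.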